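Cytotoxicity notes on a pyridazinone amide series

The compounds below may be only part of what the source reports. "The series", "measured", "known", "first", "only" and "open" are said of these compounds alone.

Measured compounds:
- compound 1, `CNC(=O)c1cc(Oc2ccc(NC(=O)c3nn(-c4ccccc4OC(F)(F)F)c(=O)cc3C)cc2F)ccn1`: > 40000 nM
- compound 2, `Cc1cc(=O)n(-c2ccc(Br)cc2F)nc1C(=O)Nc1ccc(Oc2ncnc3ccsc23)cc1`: 9360 nM

In a functional assay on MCF7 cells (Homo sapiens) for cytotoxicity, read by MTT assay, with a stated time of 72 h (a lower number here means a stronger inhibitor, a higher number a weaker inhibitor), compound 1 gives only a limit, > 40000 nM. Going by the values given here, compound 2 gives the single number in this assay, 9360 nM, and so stands alone as a measured point. The value of compound 1, by contrast, is a limit (the limit of > 40000 nM in this assay, at which 1 of the 2 values shown sits).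

Compound 3, `Cc1ccc(-n2nc(C(=O)Nc3ccc(Oc4ncnc5ccsc45)cc3)c(C)cc2=O)c(C)c1`, is not yet measured. It differs from compound 2 in one place: 2,4-dimethylphenyl in place of 4-bromo-2-fluorophenyl on an aromatic nitrogen. Among the compounds with values here, no measured step of this kind exists here, so the expected step from compound 2 to compound 3 is estimated as a 1.3-fold higher number from compound 2 to compound 3 (0.11 log units; within the scatter), not clearly beyond the scatter. Compound 3 is expected at 12000 nM, within 4000 nM to 40000 nM.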

Compound 3, half-maximal inhibitory concentration: 11900 nM
Estimate against measurement, compound 3: 1.0-fold (0.00 log units) above; low and high end bracket the measured number.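

In this assay, going by these compounds alone, this is the first one-place change at the aromatic nitrogen, and it gives a 1.3-fold higher number from compound 2 to compound 3 (0.10 log units; within the scatter) on the shared core. Exchanging 4-bromo-2-fluorophenyl for 2,4-dimethylphenyl, which removes both halogens and keeps the count of 8 heavy atoms, therefore stays within the scatter at this position. No measured property bears on the reason for this result.

Going by these compounds, whether an amine or a carboxylic acid on this aromatic ring would give a step beyond the scatter remains open. The same holds for a longer chain in place of the ring on this nitrogen.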